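Dropping one fluoro from the difluorophenyl of compound 3

The compounds below may be only part of what the source reports. "The series", "measured", "known", "first", "only" and "open" are said of these compounds alone.

Compound 1 `CC1CCN(c2c(S(=O)(=O)c3ccccc3)cnc3cc(Cl)ccc23)CC1` gives, in an assay on isolated protein for displacement of a labelled ligand from metabotropic glutamate receptor 5 (Homo sapiens), with a stated time of 60 min, tested at 1 uM (a higher number here means more inhibition at the concentration tested (going by the name of the read-out), a lower number less inhibition), a value of 93%. Compound 2 `CC1CCN(c2c(S(=O)(=O)c3ccc(F)cc3)cnc3cc(Cl)ccc23)CC1` carries a 4-fluorophenyl in place of that phenyl, and in this assay compound 2 gives 91%. The change hydrogen in place of fluoro on an aromatic carbon produced a number 2 percentage points higher from compound 2 to compound 1 (within the scatter). Compound 3 `CC1CCN(c2c(S(=O)(=O)c3ccc(F)c(F)c3)cnc3c(F)cccc23)CC1` has a 3,4-difluorophenyl and a differently substituted core; the difference between the two cores of compound 3 and compound 2 is not broken down here. In this assay compound 3 gives 93%, level with compound 1 at the digits reported. Compound 4 `CC1CCN(c2c(S(=O)(=O)c3cccc(F)c3)cnc3c(F)cccc23)CC1` has not been measured. It differs from compound 3 by hydrogen in place of fluoro on an aromatic carbon, the same kind of change as from compound 2 to compound 1, though here the site is also ortho to a fluoro group. Because the earlier change gave a number 2 percentage points higher from compound 2 to compound 1 (within the scatter), the step from compound 3 to compound 4 is expected to be a number 1 percentage points lower from compound 3 to compound 4 (within the scatter). Compound 4 is therefore estimated at 92% in this assay, between 84% and 97%.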

Compound 4, a percentage reported as inhibition, at one concentration (the size of the read-out at that concentration, not a potency): 62%
For compound 4 the middle estimate is 30 percentage points above the measured one; the measured number lies below the stated range.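

In this assay, hydrogen in place of fluoro on an aromatic carbon did not carry over from one core to the other: the same change on two cores in this assay, a number 2 percentage points higher (within the scatter) from compound 2 to compound 1 and a number 31 percentage points lower (beyond the scatter) from compound 3 to compound 4, 33 percentage points apart, beyond the scatter of two such steps On the 3,4-difluorophenyl, where the site is ortho to a fluoro group and para to a large group, the change gave a number 31 percentage points lower from compound 3 to compound 4 (beyond the scatter), so a step read on one core cannot be assumed on the other in this series. It does not show whether the core or the remaining fluoro group sets the gap, as the two pairs differ in both, and these are single-concentration read-outs rather than potencies.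

The compounds shown leave open how the 3-fluorophenyl behaves on the core of compound 1. Also open, as far as these compounds go, is whether a methoxy or a nitrile at the site of the lost fluoro would keep the number of compound 3.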